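Replacing the Piperidine Amide with a Furanylmethyl Amide

A few compounds are considered here, and "the series" means these few. Any claim that something is new, unique, unknown or untested is made for them only; others in the source may bear on it.

All numbers here come from an ADME assay on RAW264.7 cells (Mus musculus) for cytotoxicity, read by WST assay; a higher number here means that more compound is tolerated, a lower number that less compound is tolerated. Compound 3 `O=C(c1ccc(CN2C(=O)c3ccccc3S2(=O)=O)cc1)N1CCCCC1` gives 69200 nM and holds the highest of the two plain numbers, but its nearest neighbour, compound 2 `CC1=C(c2ccc3ccccc3c2)S(=O)(=O)N(Cc2ccc(C(=O)N3CCCCC3)cc2)C1=O` with 47900 nM, lies within the usual scatter of it, so the two cannot be told apart. Compound 1 `CC1=C(c2ccc(C)c(C)c2)S(=O)(=O)N(Cc2ccc(C(=O)N3CCCCC3)cc2)C1=O` reaches only a limit of this assay, > 100000 nM, as noted for (the limit of > 100000 nM in this assay, at which 1 of the 3 values shown sits). For the measured compounds named here, the single measured step, an at least 2.0-fold lower number from compound 1 to compound 2 (0.31 log units; beyond the scatter), concerns the aryl group on a double-bonded ring carbon and leaves the amide end untouched.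

Compound 4 `O=C(NCc1ccco1)c1ccc(CN2C(=O)c3ccccc3S2(=O)=O)cc1` differs from compound 3 only at that amide end: ((furan-2-yl)methyl)amino in place of piperidin-1-yl on a carbonyl carbon. Going by the values given here, no measured step touches this part of the molecule, so there is nothing to suggest a shift in either direction. The step is therefore expected to stay within the scatter, a 1.2-fold lower number from compound 3 to compound 4 (0.06 log units; within the scatter). Compound 4 is thus estimated at 60000 nM, with a range from 25000 nM to 150000 nM.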

Compound 4, concentration lethal to 50% of the cells: > 100000 nM
Compound 4 gave a limit, no number; the forecaster's own chance of this, stated with the estimate: 25%; at least 1.6-fold (0.22 log units) between middle value and limit.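

For the compounds shown here, the first measured change at the amide end is ((furan-2-yl)methyl)amino in place of piperidin-1-yl on a carbonyl carbon, and in this assay it gives an at least 1.4-fold higher number from compound 3 to compound 4 (0.15 log units; that floor lies within the scatter). Taken alone, that floor does not establish a real difference, but it does show that this position accepts the five-membered aromatic ring and the amide hydrogen without any fall in the number. Compound 4 gives a limit, not a number, so the true size of the step stays unknown: the limit of > 100000 nM in this assay, at which 2 of the 4 values shown sit.

Still open, from the compounds shown here alone, is whether the furan-2-yl ring matters at all, which a benzylamino group at the same carbonyl carbon could help to test. Also open, going by these compounds, is whether the same change would behave alike on the core of compound 1 or compound 2.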